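The source may report more compounds than this note shows. Statements on the series, on what has been measured and on what is new or still open speak of the compounds shown alone.

Among the measured compounds shown here, in a functional assay on A549 cells (Homo sapiens) for inhibition, read by MTT assay, with a stated time of 72 h (a lower number here means a stronger inhibitor, a higher number a weaker inhibitor), compound 1 `CCc1ccc(NC(=O)C2CCN(C/C=C/c3ccccc3)CC2)cc1` gives 19600 nM, the only actual number so far. Compound 2 `COc1ccccc1NC(=O)C1CCN(C/C=C/c2ccccc2)CC1` has only a limit of the assay, > 100000 nM. Compound 3 `O=C(Nc1cccc(Cl)c1)C1CCN(C/C=C/c2ccccc2)CC1` differs from compound 1 by having 3-chlorophenyl in place of 4-ethylphenyl on an amide-type nitrogen. For the measured compounds named here, the one measured step at that place, an at least 5.1-fold higher number from compound 1 to compound 2 (0.70 log units; beyond the scatter), lies beyond the scatter. It is thin ground, but it suggests that a moderately higher number should be expected in this assay. The estimated value for compound 3 is 35000 nM, with an expected range of 12000 nM to 100000 nM, which means an expected 1.8-fold higher number from compound 1 to compound 3 (0.25 log units; within the scatter).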

Compound 3, half-maximal inhibitory concentration: 19100 nM
The estimate for compound 3 lay 1.8-fold (0.26 log units) above the measured number, within the range that was stated.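

Set against the earlier loss with 2-methoxyphenyl, 3-chlorophenyl and 4-ethylphenyl on the amide-type nitrogen read alike in this assay, with a 1.0-fold lower number from compound 1 to compound 3 (0.01 log units; within the scatter), so not every replacement at this place costs activity. Exchanging 2-methoxyphenyl for 3-chlorophenyl gives an at least 5.2-fold lower number from compound 2 to compound 3 (0.71 log units; beyond the scatter), which shows that the group at this place can matter. That step has a limit of the assay at one end, not a number: the limit of > 100000 nM in this assay, at which 1 of the 3 values shown sits.

The compounds shown leave open whether an amine or a carboxylic acid in place of the chlorine would read like compound 3.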